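The source may hold more compounds than are shown below. What is called first, only, known or untested is meant among the compounds shown, and "the series" means these compounds.

Compound 1 `O=C1Nc2ccc(S(=O)(=O)N3CCOCC3)cc2/C1=N/c1ccc(Br)cc1` gives 44800 nM
Compound 2 `O=C1Nc2ccc(S(=O)(=O)N3CCOCC3)cc2/C1=N/NC(=O)c1ccccc1` gives 414000 nM
Compound 3 `O=C1Nc2ccc(S(=O)(=O)N3CCOCC3)cc2/C1=N/c1ccc(C(=O)O)cc1` gives 26700 nM

All three values come from a functional assay on MCF7 cells (Homo sapiens) for cytotoxicity, read by sulforhodamine B assay, with a stated time of 24 h; on this read-out higher numbers stand for weaker inhibition and lower numbers for stronger inhibition. Compound 3 cannot be separated from its nearest neighbour, as the data show a 1.7-fold lower number from compound 1 to compound 3 (0.22 log units; within the scatter). Its furthest neighbour is clearly apart, with a 16-fold lower number from compound 2 to compound 3 (1.19 log units; beyond the scatter).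

Compound 4 `CC(=O)c1cccc(/N=C2\C(=O)Nc3ccc(S(=O)(=O)N4CCOCC4)cc32)c1` has not yet been measured. Its change is 3-acetylphenyl in place of 4-carboxyphenyl on a double-bonded nitrogen, which in words is 3-acetylphenyl in place of 4-carboxyphenyl on a double-bonded nitrogen.

The most useful guide is the swap of bromo for carboxy on an aromatic carbon, which gave a 1.7-fold lower number from compound 1 to compound 3 (0.22 log units; within the scatter). The two steps involving benzamido were larger, namely a 9.2-fold higher number from compound 1 to compound 2 (0.97 log units; beyond the scatter) and a 16-fold lower number from compound 2 to compound 3 (1.19 log units; beyond the scatter), but benzamido plays no part in the new change. For the measured compounds named here, no measured compound carries an acetyl group, so this comparison rests on little evidence. The expectation in this assay is therefore for no step beyond the scatter, with a slight lean towards a higher number. The expected step is a 1.3-fold higher number from compound 3 to compound 4 (0.12 log units; within the scatter). Compound 4 is estimated at 35000 nM, with an expected range from 14000 nM to 90000 nM.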

Compound 4, half-maximal inhibitory concentration: 39200 nM
For compound 4 the middle estimate is 1.1-fold (0.05 log units) below the measured one, within the range that was stated.
By their numbers in this assay, from the lowest: compounds 3, 4 and 1 (each within the scatter of the next); then compound 2.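

In this assay, putting 3-acetylphenyl in place of 4-carboxyphenyl on the double-bonded nitrogen gives a 1.5-fold higher number from compound 3 to compound 4 (0.17 log units; within the scatter) and so adds a third aryl group to the set that cannot be separated, since the comparison with 4-bromophenyl gives a 1.1-fold lower number from compound 1 to compound 4 (0.06 log units; within the scatter) and these three groups differ in both their substituent and its ring position. This also shows that the 1 hydrogen-bond donor in 4-carboxyphenyl is not needed to stay within the scatter here, as 3-acetylphenyl has 0 hydrogen-bond donors, while the benzamido group in compound 2 remains the exception, with an 11-fold lower number from compound 2 to compound 4 (1.02 log units; beyond the scatter) as the step to the new compound. No measurement shown explains why these three aryl groups give such similar numbers or why benzamido stands apart.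

In the step to compound 4, the substituent and its ring position change together, so the contribution of each remains unresolved. On these data alone, it also remains open what an amine on the phenyl ring, or a longer alkyl chain in place of that ring, would do on this nitrogen.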